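Swapping chloro for methyl on the amide ring

This account rests on a few compounds, and the source may have more. Where it says the series, first, only, none or still open, it means among the compounds named here.

compound 1 `O=C(Nc1cccc(/C=C/C(=O)c2nc3ccccc3[nH]2)c1)c1cccc(Cl)c1`: 1120 nM
compound 2 `O=C(Nc1cccc(/C=C/C(=O)c2nc3ccccc3[nH]2)c1)c1ccc(Cl)cc1`: 2270 nM
compound 3 `Cc1ccccc1C(=O)Nc1cccc(/C=C/C(=O)c2nc3ccccc3[nH]2)c1`: 1870 nM

Of the compounds shown here, three built on one shared core have been tested in a functional assay on HCT-116 cells (Homo sapiens) for antiproliferative activity, read by MTT assay, with a stated time of 48 h; on this read-out lower numbers stand for stronger inhibition and higher numbers for weaker inhibition. Compound 2 gives the highest of the three numbers, meaning the weakest inhibition of the set. Its nearest neighbour is compound 3, and the two sit within the scatter of each other: a 1.2-fold lower number from compound 2 to compound 3 (0.08 log units; within the scatter). Going by the values given here, the only step beyond the scatter is a 2.0-fold higher number from compound 1 to compound 2 (0.31 log units; beyond the scatter), a modest one, while a 1.7-fold higher number from compound 1 to compound 3 (0.22 log units; within the scatter) again stays within the scatter.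

Compound 4 `Cc1ccc(C(=O)Nc2cccc(/C=C/C(=O)c3nc4ccccc4[nH]3)c2)cc1` is the next compound to be measured. Compared with compound 2, the change is methyl in place of chloro on an aromatic carbon. Among the compounds with values here, none of the measured steps exactly matches this change: the steps already seen move a group from one position of the ring to another or swap group and position at once, and every one of them is small. Within the data shown here, with no measured step pointing clearly in either direction, the expected outcome for compound 4 is a number close to that of compound 2, with a 1.1-fold lower number from compound 2 to compound 4 (0.03 log units; within the scatter) not expected to exceed the scatter. In this assay compound 4 is therefore estimated at 2100 nM, with a range from 1000 nM to 4500 nM.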

Compound 4, half-maximal inhibitory concentration: 1660 nM
The estimate for compound 4 lay 1.3-fold (0.10 log units) above the measured number, and the stated range covers the measured number.
By their numbers in this assay, from the lowest: compounds 1, 4, 3 and 2 (each within the scatter of the next, the first and the last beyond it).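

Here, for the first time, chloro and methyl are exchanged directly on one carbon of the ring, para to a large group, and in this assay the exchange gives a small step (a 1.4-fold lower number from compound 2 to compound 4 (0.14 log units; within the scatter)), so the two groups cannot be told apart at this position. The other two new comparisons point the same way: 4-methylphenyl in place of 2-methylphenyl gives (a 1.1-fold lower number from compound 3 to compound 4 (0.05 log units; within the scatter)), and 4-methylphenyl in place of 3-chlorophenyl gives (a 1.5-fold higher number from compound 1 to compound 4 (0.17 log units; within the scatter)). Compound 4 therefore sits within the scatter of every other compound in the set, which leaves the gap between compound 1 and compound 2 as the only difference beyond the scatter.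

From the compounds shown here alone, these compounds carry only chloro or methyl on this ring, so it remains open whether a quite different group at this position, such as an amine, a carboxylic acid or a longer chain, would move the number beyond the scatter. Nothing available here offers an explanation for the small size of these steps.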